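Quinoxaline sulfone anilines: dimethoxy switch on a bromo analogue

The compounds below may be only part of what the source reports. "The series", "measured", "known", "first", "only" and "open" are said of these compounds alone.

Measured so far in a functional assay on HL-60 cells (Homo sapiens) for cytotoxicity, read by MTT assay, with a stated time of 72 h; a lower number here means a stronger inhibitor, a higher number a weaker inhibitor:
compound 1 `COc1ccc(Nc2nc3ccccc3nc2S(=O)(=O)c2ccc(C)cc2)cc1` gives 2790 nM
compound 2 `COc1cc(Nc2nc3ccccc3nc2S(=O)(=O)c2ccc(C)cc2)cc(OC)c1` gives 20 nM
compound 3 `COc1ccc(Nc2nc3ccccc3nc2S(=O)(=O)c2ccc(Br)cc2)cc1` gives 1190 nM

Two changes run through the series. The first, (3,5-dimethoxyphenyl in place of 4-methoxyphenyl on a nitrogen on an aromatic ring), gives a 140-fold lower number from compound 1 to compound 2 (2.14 log units; beyond the scatter), by far the largest movement seen. The second, (bromo in place of methyl on an aromatic carbon), gives a 2.3-fold lower number from compound 1 to compound 3 (0.37 log units; beyond the scatter), a modest shift in the same direction. Compound 2 stands apart from compounds 1 and 3, each of its steps to them lying beyond the scatter.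

Compound 4 `COc1cc(Nc2nc3ccccc3nc2S(=O)(=O)c2ccc(Br)cc2)cc(OC)c1` is not yet measured. It differs from compound 3 by 3,5-dimethoxyphenyl in place of 4-methoxyphenyl on a nitrogen on an aromatic ring. Within the data shown here, this is the same change as the one from compound 1 to compound 2, made on the core of compound 3 instead of the core of compound 1; the two cores differ only by bromo in place of methyl on an aromatic carbon. Since the change has been seen in just these two pairs, and only one of them is measured, the size of the step on the second core is an expectation, not a pattern.

For compound 4 a step of a 99-fold lower number from compound 3 to compound 4 (2.00 log units; beyond the scatter) is expected in this assay, set beside a 140-fold lower number from compound 1 to compound 2 (2.14 log units; beyond the scatter), because compound 3 starts from 1190 nM and the earlier step was large. A somewhat smaller step is allowed for, as the earlier change was seen only once. Compound 4 is estimated at 12 nM, between 3 nM and 50 nM.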

Compound 4, half-maximal inhibitory concentration: 2540 nM
The estimate for compound 4 lay 210-fold (2.33 log units) below the measured number, and the stated range ends below it.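

In this assay, 3,5-dimethoxyphenyl in place of 4-methoxyphenyl does not carry over from the core of compound 1 to the core of compound 3, where it gives a 2.1-fold higher number from compound 3 to compound 4 (0.33 log units; beyond the scatter), so the large drop seen on the first core does not appear on the second: the same change on two cores in this assay, a 140-fold lower number (2.14 log units; beyond the scatter) from compound 1 to compound 2 and a 2.1-fold higher number (0.33 log units; beyond the scatter) from compound 3 to compound 4, 300-fold (2.47 log units) apart, beyond the scatter of two such steps

Read along the other edge of the same four compounds, bromo in place of methyl gives a 130-fold higher number from compound 2 to compound 4 (2.10 log units; beyond the scatter), whereas the same change with 4-methoxyphenyl gave a modest step in the opposite direction: the same change on two cores in this assay, a 2.3-fold lower number (0.37 log units; beyond the scatter) from compound 1 to compound 3 and a 130-fold higher number (2.10 log units; beyond the scatter) from compound 2 to compound 4, 300-fold (2.47 log units) apart, beyond the scatter of two such steps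

The two changes therefore do not add up in this set, and among these four compounds only compound 2, which pairs 3,5-dimethoxyphenyl with methyl, reaches a low number (20 nM), but this single set of four compounds does not show why, nor how far the dependence extends beyond them.

Still open, going by these compounds, is whether chloro or ethyl in place of methyl on that aromatic carbon would keep the large step or lose it. A single methoxy group moved elsewhere on the aniline ring, or a hydroxy group in its place, would also remain to be placed against these results.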